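Swapping fluoro for trifluoromethyl on the aromatic ring

A few compounds are considered here, and "the series" means these few. Any claim that something is new, unique, unknown or untested is made for them only; others in the source may bear on it.

Within the data shown here, in a functional assay on MDA-MB-231 cells (Homo sapiens) for antiproliferative activity, read by MTT assay, with a stated time of 72 h (a higher number here means a weaker inhibitor, a lower number a stronger inhibitor), compound 2 `CC1=CC[C@H]2[C@H](CC[C@]2(C)O)C(C)(C)[C@@H]1CC[C@H]1[C@]2(C)CC[C@H](OC(=O)c3ccccc3F)C(C)(C)O[C@H]2CC[C@@]1(C)O` gives 28700 nM as one of only two measured values. The other belongs to compound 1 `CC1=CC[C@H]2[C@H](CC[C@]2(C)O)C(C)(C)[C@@H]1CC[C@H]1[C@]2(C)CC[C@H](OC(=O)NS(=O)(=O)c3ccc(C)cc3)C(C)(C)O[C@H]2CC[C@@]1(C)O` at 47100 nM on the same core. The gap is a 1.6-fold lower number from compound 1 to compound 2 (0.22 log units; within the scatter) and so neither compound can be ranked above the other. Compound 3 `CC1=CC[C@H]2[C@H](CC[C@]2(C)O)C(C)(C)[C@@H]1CC[C@H]1[C@]2(C)CC[C@H](OC(=O)c3ccccc3C(F)(F)F)C(C)(C)O[C@H]2CC[C@@]1(C)O` differs from compound 2 in one place, with trifluoromethyl in place of fluoro on an aromatic carbon and ortho to a large group. Among the measured compounds shown here, the single measured step replaced a different group, with 2-fluorophenyl in place of ((4-methylphenyl)sulfonyl)amino on a carbonyl carbon, so it offers only weak guidance. For the measured compounds named here, no measured step tests the new swap, so no change beyond the scatter is expected in this assay for now. The expected step is a 1.1-fold lower number from compound 2 to compound 3 (0.03 log units; within the scatter) in this estimate. Compound 3 is estimated at 27000 nM with an expected range from 13000 nM to 55000 nM for repeated measurements.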

Compound 3, half-maximal inhibitory concentration: 31500 nM
Beside the measured number, compound 3's estimate is 1.2-fold (0.07 log units) below it; the range from low to high includes it.
By their numbers in this assay, from the lowest: compounds 2, 3 and 1 (each within the scatter of the next).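

In this assay, the step at this aromatic carbon, ortho to a large group, reads a 1.1-fold higher number from compound 2 to compound 3 (0.04 log units; within the scatter) and so shows that, on the shared core, fluoro and trifluoromethyl cannot be told apart here, even though the entering group has 4 heavy atoms and the leaving group has 1. The 2-(trifluoromethyl)phenyl group also cannot be separated from the ((4-methylphenyl)sulfonyl)amino group on the carbonyl carbon, with a 1.5-fold lower number from compound 1 to compound 3 (0.17 log units; within the scatter) as the step between them, so compounds 1, 2 and 3 all lie within the scatter. Nothing available gives a reason for this result.

The compounds shown leave open what an amine or a carboxylic acid on the same aromatic carbon would give. They also leave open how the unsubstituted phenyl ring compares.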